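The source may hold more compounds than are shown below. What is called first, only, known or untested is meant among the compounds shown, and "the series" means these compounds.

Compound 1, `O=C(COc1ccc2c(=O)cc(-c3ccccc3)oc2c1)Nc1ccccc1`: > 10000 nM
Compound 2, `O=C(COc1ccc2c(=O)c(-c3ccccc3)coc2c1)Nc1ccccc1`: > 10000 nM

In a functional assay on NCI-H661 cells (Homo sapiens) for antiproliferative activity, read by MTT assay, with a stated time of 72 h (a lower number here means a stronger inhibitor of growth, a higher number a weaker inhibitor of growth), compound 2 gives > 10000 nM, which is a limit of the assay, not a number. Compound 1 likewise reaches only a limit, (the limit of > 10000 nM in this assay, at which 2 of the 2 values shown sit). Compound 3, `COc1ccc(NC(=O)COc2ccc3c(=O)c(-c4ccccc4)coc3c2)cc1`, has not yet been measured; it differs from compound 2 by methoxy in place of hydrogen on an aromatic carbon. Going by the values given here, with both measured compounds at the limit, there is no step to lean on, so no change beyond the usual scatter is expected, and the estimated step from a step that the limit leaves unreadable from compound 2 to compound 3 is small. Compound 3 is expected at about 15000 nM, between 5000 nM and 50000 nM.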

Compound 3, concentration for 50% growth inhibition: 9530 nM
For compound 3 the middle estimate is 1.6-fold (0.20 log units) above the measured one; measured number inside the range.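

Methoxy on this aromatic carbon gives the first number in this assay that is not a limit, yet the change can be stated only as an at least 1.0-fold lower number from compound 2 to compound 3 (0.02 log units; that floor lies within the scatter). The compounds therefore show no gain beyond the scatter, only a reading that falls close to the limit. Only a floor can be given because compound 2 sits at a limit: the limit of > 10000 nM in this assay, at which 2 of the 3 values shown sit.

On these data alone, the true size of the step stays open. As far as these compounds go, whether an amine or a carboxylic acid at this position would move the number further also remains unknown, as does the effect of methoxy on the core of compound 1.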